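From bromo to thiophene on a shared core

The compounds below may be only part of what the source reports. "The series", "measured", "known", "first", "only" and "open" are said of these compounds alone.

Compound 1 `O=C(Nc1ccccn1)c1cc(=O)[nH]c2cc(Br)ccc12`: > 20000 nM (a limit of the assay)
Compound 2 `O=C(Nc1cccc(F)c1)c1cc(=O)[nH]c2cc(Br)ccc12`: 10600 nM

For the measured compounds named here, in a functional assay on SK-OV-3 cells (Homo sapiens) for antiproliferative activity, read by MTT assay, with a stated time of 72 h (a lower number here means a stronger inhibitor, a higher number a weaker inhibitor), compound 2 gives the only actual number so far, 10600 nM. For compound 1 there is only a limit (the limit of > 20000 nM in this assay, at which 1 of the 2 values shown sits). Compound 3 `O=C(Nc1cccc(F)c1)c1cc(=O)[nH]c2cc(-c3ccsc3)ccc12` differs from compound 2 in one place: thiophen-3-yl in place of bromo on an aromatic carbon. Going by the values given here, the one measured step, an at least 1.8-fold lower number from compound 1 to compound 2 (0.27 log units; that floor lies within the scatter), has a floor within the scatter and concerns the group on the amide-type nitrogen, so it bears only weakly on this change. Only a modest shift is therefore expected, slightly towards a lower number, with the direction uncertain: a 1.5-fold lower number from compound 2 to compound 3 (0.18 log units; within the scatter). For compound 3 the estimated value is 7000 nM, with an expected range of 1800 nM to 20000 nM.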

Compound 3, half-maximal inhibitory concentration: 6700 nM
Estimate against measurement, compound 3: 1.0-fold (0.02 log units) above, within the range that was stated.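

In this assay, putting thiophen-3-yl in place of bromo gives a 1.6-fold lower number from compound 2 to compound 3 (0.20 log units; within the scatter). This is the first step shown at this place on the shared core, and it shows that a whole five-membered aromatic ring can replace bromo with no change that can be told apart from scatter. No measurement shown explains this result.

Going by these compounds, whether an amine, a carboxylic acid or a longer chain at this place would give a step beyond the scatter remains open. So does whether thiophen-3-yl would give the same result with pyridin-2-yl in place of 3-fluorophenyl on the amide-type nitrogen.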